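The compounds below may be only part of what the source reports. "The series", "measured", "known", "first", "only" and "open" are said of these compounds alone.

In a functional assay on A-375 cells (Homo sapiens) for inhibition, read by MTT assay, with a stated time of 120 h (a lower number here means a stronger inhibitor, a higher number a weaker inhibitor), compound 3 `C/C(=C\C(=O)N1CC(C)OC(C)C1)c1ccc(NC(=O)Nc2ccc(Cl)c(C(F)(F)F)c2)cc1` gives 46200 nM, the higher of the two numeric values, while compound 1 `CNC(=O)/C=C/c1ccc(NC(=O)Nc2ccc(Cl)c(C(F)(F)F)c2)cc1` gives 20900 nM. Compound 2 `O=C(CCc1ccc(NC(=O)Nc2ccc(Cl)c(C(F)(F)F)c2)cc1)NC1CCC1` reaches only a limit, > 50000 nM. Compound 4 `CNC(=O)/C=C(\C)c1ccc(NC(=O)Nc2ccc(Cl)c(C(F)(F)F)c2)cc1` differs from compound 3 by methylamino in place of 2,6-dimethylmorpholin-4-yl on a carbonyl carbon, and so carries the methylcarbamoyl group also found in compound 1. Among the measured compounds shown here, the only measured step, an at least 2.3-fold higher number from compound 1 to compound 2 (0.37 log units; beyond the scatter), changes that same amide position, but its size is bounded by a limit and it alters the chain as well, so it gives only loose guidance. A small move to a lower number is expected, towards the 20900 nM of compound 1. The estimated change is a 1.8-fold lower number from compound 3 to compound 4 (0.27 log units; within the scatter), possibly no larger than the scatter. Compound 4 is expected at 25000 nM, with an estimated range of 11000 nM to 50000 nM.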

Compound 4, half-maximal inhibitory concentration: > 50000 nM
Compound 4 was reported as a limit (the forecaster's own chance of this, stated with the estimate: 15%); middle value at least 2.0-fold (0.30 log units) from the limit.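

In this assay, 1-methyl-2-(methylcarbamoyl)ethenyl in place of 2-(methylcarbamoyl)ethenyl gives an at least 2.3-fold higher number from compound 1 to compound 4 (0.37 log units; beyond the scatter), so the methylcarbamoyl group alone does not keep the level of compound 1. Methylamino in place of 2,6-dimethylmorpholin-4-yl on the carbonyl carbon gives an at least 1.0-fold higher number from compound 3 to compound 4 (0.03 log units; that floor lies within the scatter), so this change shows no gain. The step between compound 2 and compound 4 cannot be read, because both are limits: the limit of > 50000 nM in this assay, at which 2 of the 4 values shown sit.

Still open, on these data alone, is how far the true value of compound 4 lies past its limit. Also open, as far as these compounds go, is whether a carboxylic acid or an amine-bearing chain on that carbonyl carbon would give a lower number.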